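This account rests on a few compounds, and the source may have more. Where it says the series, first, only, none or still open, it means among the compounds named here.

Four compounds sharing one core are compared in a functional assay on COLO 205 cells (Homo sapiens) for cytotoxicity (on this read-out higher numbers stand for weaker inhibition and lower numbers for stronger inhibition), here. Compound 1 (`COc1ccc(Cn2nc(Nc3cc(C)[nH]n3)c3ccccc3c2=O)cc1`) gives 4200 nM and compound 2 (`Cc1cc(Nc2nn(-c3ccc(F)cc3)c(=O)c3ccccc23)n[nH]1`) gives 1600 nM on this read-out. Compound 3 (`Cc1cc(Nc2nn(CC(C)C)c(=O)c3ccccc23)n[nH]1`) has no number to stand on: its result reads "not determined" (no result reported) and it cannot be placed relative to the other two. Compound 4 (`Cc1cc(Nc2nn(Cc3csc(C)n3)c(=O)c3ccccc23)n[nH]1`) departs from compound 3 by one change, (2-methyl-1,3-thiazol-4-yl in place of isopropyl on a saturated chain carbon bound to an aromatic nitrogen), that is, 2-methyl-1,3-thiazol-4-yl in place of isopropyl on a saturated chain carbon bound to an aromatic nitrogen. Among the compounds with values here, only one measured step bears on this, and only indirectly: a 2.6-fold lower number from compound 1 to compound 2 (0.42 log units; beyond the scatter), with 4-fluorophenyl in place of 4-methoxybenzyl on an aromatic nitrogen. With no value for compound 3, that step cannot be applied from a starting point, and it gives no direction for the new group. The expectation in this assay is therefore a position near the two measured compounds, with a change of similarly modest size at most. Compound 4 is expected at about 2500 nM, with an estimated range from 800 nM to 8000 nM.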

Compound 4, half-maximal inhibitory concentration: > 30000 nM
Compound 4: a limit, no number (the forecaster's own chance of this, stated with the estimate: 10%); at least 12-fold (1.07 log units) between middle value and limit.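

Compound 4 gives > 30000 nM in this assay, which is a limit of the assay and not a number, and it is the only compound shown there: the limit of > 30000 nM in this assay, at which 1 of the 4 values shown sits. The group on the aromatic nitrogen can therefore shift this read-out by a large step, not only the modest one seen earlier, as (2-methyl-1,3-thiazol-4-yl)methyl gives an at least 18-fold higher number from compound 2 to compound 4 (1.27 log units; beyond the scatter) and an at least 7.1-fold higher number from compound 1 to compound 4 (0.85 log units; beyond the scatter). As far as these compounds go, the step from compound 3 to compound 4 cannot be read, so the direct effect of replacing isobutyl stays unknown.

The compounds shown leave open how far beyond its limit compound 4 lies and whether the methyl on its 2-methyl-1,3-thiazol-4-yl group matters. They also do not show how a plain benzyl or a pyridinylmethyl group on that nitrogen would read.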